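Swapping pyrrolidin-1-yl for dimethylamino in compound 3

The compounds below may be only part of what the source reports. "The series", "measured", "known", "first", "only" and "open" are said of these compounds alone.

Compound 1 `CC(C)Oc1cc(-c2ccc(O)c(O)c2)nc2ccccc12`: 20 nM
Compound 2 `Cc1cc2oc(-c3ccc(O)c(O)c3)cc(=O)c2cc1C`: 250 nM
Compound 3 `Cc1cc2oc(-c3ccc(N4CCCC4)cc3)cc(=O)c2cc1C`: > 500 nM

These results come from a functional assay on HT-22 cells (Mus musculus), read by MTT assay, with a stated time of 24 h; a higher number here means that more compound is needed for the effect, a lower number that less compound is needed. There, compound 1 gives 20 nM and compound 2 gives 250 nM, so both have exact numbers. Compound 3 has only a limit, > 500 nM, and no exact number.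

The next compound to be measured is compound 4 `Cc1cc2oc(-c3ccc(N(C)C)cc3)cc(=O)c2cc1C`. It has the same core as compound 3, but dimethylamino replaces pyrrolidin-1-yl on an aromatic carbon, para to a large group: dimethylamino in place of pyrrolidin-1-yl on an aromatic carbon.

Within the data shown here, no two measured compounds differ in just one place, so no measured step can serve as a guide. The expectation therefore rests on the limit of compound 3, > 500 nM. In this assay, the expected step that the limit leaves unreadable from compound 3 to compound 4 is no larger than the usual scatter, so no clear direction is expected. For compound 4, the estimated value is 600 nM, with an expected range from 200 nM to 1500 nM.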

Compound 4, half-maximal effective concentration: > 500 nM
Compound 4 was reported as a limit (the forecaster's own chance of this, stated with the estimate: 60%); the middle value does not contradict the limit.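

Among these compounds, compound 3 and compound 4 both stand only as limits, so no step between them can be read: the limit of > 500 nM in this assay, at which 2 of the 4 values shown sit.

The compounds shown leave open whether dimethylamino and pyrrolidin-1-yl differ at all in this assay, and how far beyond that limit either compound lies.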